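The compounds below may be only part of what the source reports. "The series", "measured", "known", "first", "only" and "open" are said of these compounds alone.

Compound 1, `COc1cc(/C=C/C(=O)C2=C(/C=C/c3ccc(O)c(OC)c3)NC(=S)NC2c2ccccc2)ccc1O`, gives 15.5% in a functional assay, with a stated time of 20 min, tested at 2 uM; a higher number here means a stronger effect of the compound at the concentration tested, a lower number a weaker effect.
Compound 2, `COc1cc(/C=C/C(=O)C2=C(/C=C/c3ccc(O)c(OC)c3)NC(=S)NC2c2ccc(N(C)C)cc2)ccc1O`, gives 30.2% in this assay.
Compound 3, `COc1cc(/C=C/C(=O)C2=C(/C=C/c3ccc(O)c(OC)c3)NC(=S)NC2c2c(Cl)cccc2Cl)ccc1O`, gives 17.7% in this assay.

Compound 3 stands second highest of the three numbers: the gap a number 2.2 percentage points higher from compound 1 to compound 3 (within the scatter) is within the scatter, while a number 12.5 percentage points lower from compound 2 to compound 3 (beyond the scatter) is beyond it. Compound 4, `COc1cc(/C=C/C(=O)C2=C(/C=C/c3ccc(O)c(OC)c3)NC(=S)NC2c2ccccc2Cl)ccc1O`, differs from compound 3 by hydrogen in place of chloro on an aromatic carbon. Going by the values given here, the only measured step that touches this part of the molecule is a number 2.2 percentage points higher from compound 1 to compound 3 (within the scatter), which added both chloro groups without a change beyond the scatter; the step of a number 14.7 percentage points higher from compound 1 to compound 2 (beyond the scatter) concerns a different group and does not bear here. Removing one chloro is therefore expected to give no step beyond the scatter, a number 0.7 percentage points lower from compound 3 to compound 4 (within the scatter). Compound 4 is estimated at 17%, in a range from 8% to 27%.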

Compound 4, a percentage reported as activity, at one concentration (the size of the read-out at that concentration, not a potency): 16.2%
Estimate against measurement, compound 4: 0.8 percentage points above; low and high end bracket the measured number.
By their numbers in this assay, from the lowest: compounds 1, 4 and 3 (each within the scatter of the next); then compound 2.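

Taken singly, neither chloro on this ring moves the number in this assay beyond the scatter: the first, on the plain phenyl, gives a small step (a number 0.7 percentage points higher from compound 1 to compound 4 (within the scatter)), and removing the second from the 2,6-dichlorophenyl gives another (a number 1.5 percentage points lower from compound 3 to compound 4 (within the scatter)). The 2-chlorophenyl also stays well short of the 4-(dimethylamino)phenyl (a number 14 percentage points lower from compound 2 to compound 4 (beyond the scatter)), so among these compounds only compound 2 stands apart. Nothing available explains these numbers. As far as these compounds go, whether a methoxy group or a morpholine on this phenyl would match the dimethylamino group remains open.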